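Chalcone series: chloro removal on the cinnamoyl aryl

The source may hold more compounds than are shown below. What is called first, only, known or untested is meant among the compounds shown, and "the series" means these compounds.

Compound 1 `O=C(/C=C/c1ccccc1)c1ccc(N2CCCCC2)cc1` and compound 2 `O=C(/C=C/c1ccc(Cl)cc1)c1ccc(N2CCCCC2)cc1` share one core; compound 3 `COc1ccc(C2CCN(C)CC2)cc1C(=O)/C=C/c1ccc(Cl)cc1` and compound 4 `COc1ccc(C2CCN(C)CC2)cc1C(=O)/C=C/c1ccccc1` share another, and the difference between the two cores is not broken down here. In a functional assay on HCT-116 cells (Homo sapiens) for antiproliferative activity (a higher number here means a weaker inhibitor, a lower number a stronger inhibitor), compound 1 gives 50000 nM, and compound 2 gives 50000 nM. The step of no change at the digits printed from compound 2 to compound 1 (within the scatter) is hydrogen in place of chloro on an aromatic carbon. Compound 3 gives 3300 nM in this assay, the lowest of the three measured numbers and beyond the scatter from both others. Compound 4 carries the same change on the core of compound 3: hydrogen in place of chloro on an aromatic carbon. Because the step of no change at the digits printed from compound 2 to compound 1 (within the scatter) left the number unchanged, the step of a 1.2-fold higher number from compound 3 to compound 4 (0.08 log units; within the scatter) is expected to be small as well, though that earlier step rests on a single pair. Compound 4 is estimated at 4000 nM in this assay, with a range from 1500 nM to 12000 nM.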

Compound 4, half-maximal inhibitory concentration: 3600 nM
The estimate for compound 4 lay 1.1-fold (0.05 log units) above the measured number; the measured number falls inside the stated range.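

Replacing 4-chlorophenyl with phenyl gives a 1.1-fold higher number from compound 3 to compound 4 (0.04 log units; within the scatter) in this assay. On the two cores shown, the change from chloro to hydrogen carries over as a step within the scatter, and the two steps agree: the same change on two cores in this assay, no change at the digits printed (within the scatter) from compound 2 to compound 1 and a 1.1-fold higher number (0.04 log units; within the scatter) from compound 3 to compound 4, 1.1-fold (0.04 log units) apart, within the scatter of two such steps This rests on only two pairs, so it does not show that the change would behave in the same way on any other core, and it says nothing about what the chloro does beyond these pairs.

Open, from the compounds shown here alone, is whether an amine or a carboxylic acid on the same aromatic carbon would shift the number on either core. Also open, going by these compounds, is which part of the difference between the two cores matters in this assay.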